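The source may hold more compounds than are shown below. What is called first, only, known or untested is meant among the compounds shown, and "the series" means these compounds.

Three analogues on one shared core have been run in a physicochemical assay for solubility, measured as kinetic solubility, at pH 2; a lower number here means a less soluble compound, a higher number a more soluble compound. Compound 1 `CC(C)C(Nc1nccs1)c1ccc(-c2ccc3cccc(F)c3c2)[nH]c1=O` gives 32900 nM; compound 2 `CC(C)C(/C=C1\CCNC1=O)c1ccc(-c2ccc3cccc(F)c3c2)[nH]c1=O` gives 23600 nM; compound 3 `CC(C)C(c1ccc(-c2ccc3cccc(F)c3c2)[nH]c1=O)N1CCN/C1=N\C#N` gives 32500 nM. Compound 3 thus sits second highest of the three numbers, though a 1.0-fold lower number from compound 1 to compound 3 (0.01 log units; within the scatter) and a 1.4-fold higher number from compound 2 to compound 3 (0.14 log units; within the scatter) both fall within the scatter, as does a 1.4-fold lower number from compound 1 to compound 2 (0.14 log units; within the scatter). Compound 4 `CC(C)C(c1noc(=O)[nH]1)c1ccc(-c2ccc3cccc(F)c3c2)[nH]c1=O` carries a further exchange at the saturated chain carbon bound to an aromatic carbon and a saturated chain carbon: a group of 6 heavy atoms (2 carbon, 2 nitrogen, 2 oxygen; one five-membered aromatic ring with 3 hetero atoms) in place of a group of 8 heavy atoms (4 carbon, 4 nitrogen; one five-membered non-aromatic ring with 2 hetero atoms), on a saturated chain carbon bound to an aromatic carbon and a saturated chain carbon. All three measured steps bear on this, since each swaps the group on that carbon, and none moved the readout beyond the scatter. A step within the scatter is therefore expected, namely a 1.1-fold lower number from compound 3 to compound 4 (0.03 log units; within the scatter). For compound 4 the solubility is estimated at 30000 nM, within 15000 nM to 60000 nM.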

Compound 4, solubility: 23200 nM
Beside the measured number, compound 4's estimate is 1.3-fold (0.11 log units) above it, and the stated range covers the measured number.
By their numbers in this assay, from the lowest: compounds 4, 2, 3 and 1 (each within the scatter of the next).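

Exchanging the group on the saturated chain carbon bound to an aromatic carbon and a saturated chain carbon again leaves this assay within the scatter (a 1.4-fold lower number from compound 3 to compound 4 (0.15 log units; within the scatter); a 1.0-fold lower number from compound 2 to compound 4 (0.01 log units; within the scatter); a 1.4-fold lower number from compound 1 to compound 4 (0.15 log units; within the scatter)). Among these compounds, the five-membered aromatic ring with 3 hetero atoms thus joins the earlier groups, and no pair among the four compounds separates at this position. No evidence bearing on this result is available.

As far as these compounds go, whether an amine or a carboxylic acid on this carbon would separate from these four compounds remains open. So does whether a longer chain there would.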